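Varying the acyl group on the piperidine carbamate of compound 1

The source may report more compounds than this note shows. Statements on the series, on what has been measured and on what is new or still open speak of the compounds shown alone.

Measured compounds:
compound 1 `CCC1(OC(=O)N2CCC(Oc3ncnc(Oc4ccc(S(C)(=O)=O)nc4C)c3F)CC2)CC1` gives 83%
compound 2 `Cc1nc(S(C)(=O)=O)ccc1Oc1ncnc(OC2CCN(C(=O)OC3(C(F)(F)F)CCC3)CC2)c1F` gives 82%
compound 3 `Cc1nc(S(C)(=O)=O)ccc1Oc1ncnc(OC2CCN(C(=O)SC(C)(C)C)CC2)c1F` gives 76%

All three compounds share one core and differ only in the group on the carbonyl carbon. In a functional assay on isolated protein for inhibition of Glucose-dependent insulinotropic receptor (Rattus norvegicus), read by HTRF and cAMP accumulation (on this read-out lower numbers stand for smaller maximal responses and higher numbers for larger maximal responses), compound 1 gives 83%. On the numbers shown it has the highest of the three values, but its neighbours lie close: the step of a number 1 percentage points lower from compound 1 to compound 2 (within the scatter) and the step of a number 7 percentage points lower from compound 1 to compound 3 (within the scatter) both stay within the usual scatter of repeated measurements. Between compound 2 and compound 3 the step of a number 6 percentage points lower from compound 2 to compound 3 (within the scatter) is likewise within the scatter.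

Compound 4 `Cc1nc(S(C)(=O)=O)ccc1Oc1ncnc(OC2CCN(C(=O)C3(F)CCC3)CC2)c1F` has not yet been measured. It differs from compound 1 by a group of 5 heavy atoms (4 carbon, 1 fluorine; one four-membered non-aromatic ring of carbon only) in place of a group of 6 heavy atoms (5 carbon, 1 oxygen; one three-membered non-aromatic ring of carbon only), on a carbonyl carbon. Every measured step that changes the group on this carbonyl carbon has stayed within the scatter, whether the group swapped in was a ring bearing a trifluoromethyl, as in compound 2, or a chain on sulfur, as in compound 3. On that basis compound 4 is expected to show no step beyond the scatter, with the estimated change being a number 5 percentage points lower from compound 1 to compound 4 (within the scatter). Compound 4 is therefore estimated at 78% in this assay, within a range from 66% to 90%.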

Compound 4, largest response reached (reported as efficacy), in percent of the reference or control that the assay uses: 91%
Beside the measured number, compound 4's estimate is 13 percentage points below it; the whole stated range lies below it.
By their numbers in this assay, from the lowest: compounds 3, 2, 1 and 4 (each within the scatter of the next, the first and the last beyond it).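

In this assay, going by these compounds alone, compound 4 supplies the only step at this carbonyl carbon that lies beyond the scatter: the step of a number 15 percentage points higher from compound 3 to compound 4 (beyond the scatter) sets a fluorine-bearing four-membered ring against a chain on sulfur, so the position is not wholly indifferent to the group it carries. That difference does not extend to the groups on oxygen, since the step of a number 8 percentage points higher from compound 1 to compound 4 (within the scatter) and the step of a number 9 percentage points higher from compound 2 to compound 4 (within the scatter) both stay within the scatter, leaving compound 4 unseparated from compound 1 and compound 2. Compound 4 also shows that the group with an oxygen and one hydrogen-bond acceptor in compound 1 can give way to a group with no hydrogen-bond acceptor while the maximal response stays within the scatter of compound 1.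

The compounds shown cannot say whether the step from compound 3 follows from the ring, the fluorine or the loss of sulfur, and a plain cyclobutyl group or a tert-butyl chain on oxygen would bear on that. Nothing available accounts for the step from compound 3 to compound 4.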